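The compounds below may be only part of what the source reports. "The series", "measured", "known", "first", "only" and "open" are said of these compounds alone.

Working notes on the series. The shared core carries, on its five-membered aromatic ring, an aryl or alkyl group that is varied across three compounds. Compound 1 `CC(C)c1ccc(-c2nc(CN3CCN(c4ccnc5cc(-c6cccnc6)ccc45)CC3)no2)cc1` and compound 2 `Cc1cccc(-c2nc(CN3CCN(c4ccnc5cc(-c6cccnc6)ccc45)CC3)no2)c1C` have been run in an ADME assay on the whole organism (Mus musculus, strain BALB/c) for metabolic stability, at a dose of 30 mg/kg by the oral route; on this read-out higher numbers stand for a longer-lived compound and lower numbers for a shorter-lived compound. Compound 1 gives 1.05 h. Among the measured compounds shown here, compound 2 gives 0.94 h; the only step measured so far is a 1.1-fold lower number from compound 1 to compound 2 (0.05 log units; within the scatter), so the two numbers cannot be told apart on this read-out.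

Compound 3 `c1cncc(-c2ccc3c(N4CCN(Cc5noc(C6CCCC6)n5)CC4)ccnc3c2)c1` is the next member and differs from compound 2 by cyclopentyl in place of 2,3-dimethylphenyl on an aromatic carbon. For the measured compounds named here, the one step that bears on this change is a 1.1-fold lower number from compound 1 to compound 2 (0.05 log units; within the scatter), a swap of the group at the same position that moved nothing beyond the scatter. Nothing recorded points to a direction for an alkyl ring at this position, so a shift for compound 3 in this assay is expected to be a 1.1-fold higher number from compound 2 to compound 3 (0.03 log units; within the scatter), that is none beyond the scatter. The estimate for compound 3 is 1 h, expected within 0.5 h to 2 h.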

Compound 3, half-life: 0.75 h
For compound 3 the middle estimate is 1.3-fold (0.12 log units) above the measured one; the measured number falls inside the stated range.
By their numbers in this assay, from the lowest: compounds 3, 2 and 1 (each within the scatter of the next).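

In this assay, the change from an aromatic ring to a non-aromatic one at this position gives a 1.3-fold lower number from compound 2 to compound 3 (0.10 log units; within the scatter), and the comparison with the 4-isopropylphenyl compound gives a 1.4-fold lower number from compound 1 to compound 3 (0.15 log units; within the scatter). Both steps stay within the scatter, so cyclopentyl, with its five-membered carbon ring and 5 heavy atoms, cannot be told apart from either aryl group, and the earlier aryl-to-aryl step alone could not show this. No measurement on hand bears on why the half-life stays within the scatter across these groups.

On these data alone, all three groups are carbon-only rings, so what a group with heteroatoms, such as an amine or a carboxylic acid, would do at this position stays open. A longer open alkyl chain is equally untested by these compounds, and so is any change elsewhere on the shared core.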